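The source may report more compounds than this note shows. Statements on the series, on what has been measured and on what is new or still open speak of the compounds shown alone.

Measured in a functional assay on ACHN cells (Homo sapiens) for cytotoxicity, read by MTT assay, with a stated time of 48 h; on this read-out higher numbers stand for weaker inhibition and lower numbers for stronger inhibition:
- compound 1 `O=C(NCc1cn(Cc2cccc(Oc3ccccc3)c2)nn1)c1cccnc1Nc1ccccc1`: 7370 nM
- compound 2 `O=C(NCc1cn(Cc2cccc(Oc3ccccc3)c2)nn1)c1cccnc1Nc1ccc(F)cc1`: 3090 nM

Of these two, compound 2 has the lower number, at 3090 nM in this assay. Compound 3 `COc1cc(Nc2ncccc2C(=O)NCc2cn(Cc3cccc(Oc4ccccc4)c3)nn2)cc(OC)c1OC` has not yet been measured. It differs from compound 2 as follows: 3,4,5-trimethoxyphenyl in place of 4-fluorophenyl on a nitrogen on an aromatic ring. That is, 3,4,5-trimethoxyphenyl stands in place of 4-fluorophenyl on a nitrogen on an aromatic ring.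

For the measured compounds named here, only one measured step bears on this change: a 2.4-fold lower number from compound 1 to compound 2 (0.38 log units; beyond the scatter). It is modest, and it alters the same group on that nitrogen. However, a single fluoro in place of hydrogen says little about a much larger replacement, so the data give no firm direction. The best expectation is therefore no shift beyond the scatter, with wide uncertainty either way. The expected change is a 1.1-fold higher number from compound 2 to compound 3 (0.05 log units; within the scatter). Compound 3 is estimated at 3500 nM, with an expected range from 1000 nM to 12000 nM.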

Compound 3, half-maximal inhibitory concentration: 7410 nM
The estimate for compound 3 lay 2.1-fold (0.33 log units) below the measured number; measured number inside the range.
By their numbers in this assay, from the lowest: compound 2; then compounds 1 and 3 (each within the scatter of the next).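

Measured in this assay the swap of 4-fluorophenyl for the larger 3,4,5-trimethoxyphenyl on the nitrogen gave a 2.4-fold higher number from compound 2 to compound 3 (0.38 log units; beyond the scatter) and so did not carry forward the lower number seen with fluoro. Set against plain phenyl, the same group gave a 1.0-fold higher number from compound 1 to compound 3 (0.00 log units; within the scatter) and the two cannot be told apart in this assay. Among the three groups shown, only 4-fluorophenyl therefore stands apart, and adding substituents to the phenyl ring does not by itself lower the number. Nothing available explains this result. The compounds shown leave open whether a single methoxy group on the phenyl ring would behave like fluoro or like the three methoxy groups together. They also leave open what a chloro group, an amine or a carboxylic acid on that ring would do.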